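Swapping a tert-butyl group for dipropylamino on two related cores

This account rests on a few compounds, and the source may have more. Where it says the series, first, only, none or still open, it means among the compounds named here.

Measured so far:
compound 1, `CC(C)(C)CC#Cc1cc2ncnc(Nc3ccc(OCc4cccc(F)c4)c(Cl)c3)c2s1`, 29.3 uM
compound 2, `CCCN(CC#Cc1cc2ncnc(Nc3ccc(OCc4cccc(F)c4)c(Cl)c3)c2s1)CCC`, 26.5 uM
compound 3, `CC(C)(C)CC#Cc1cc2c(Nc3ccc(OCc4cccc(F)c4)c(Cl)c3)ncnc2s1`, > 32 uM

Compound 1 and compound 2 were both tested in an ADME assay on HepG2 cells (Homo sapiens) for cytotoxicity; on this read-out lower numbers stand for higher toxicity in this test and higher numbers for lower toxicity in this test. The change between them is dipropylamino in place of tert-butyl on a saturated chain carbon bound to a triple-bonded carbon, and it made a 1.1-fold lower number from compound 1 to compound 2 (0.04 log units; within the scatter), so the two numbers cannot be told apart.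

Compound 3 carries the same atoms as compound 1 joined in a different order; the difference between the two cores is not broken down here. For compound 3 this assay gave only a limit rather than a number, (the limit of > 32 uM in this assay, at which 1 of the 3 values shown sits).

Compound 4, `CCCN(CC#Cc1cc2c(Nc3ccc(OCc4cccc(F)c4)c(Cl)c3)ncnc2s1)CCC`, has not been measured. It differs from compound 3 by dipropylamino in place of tert-butyl on a saturated chain carbon bound to a triple-bonded carbon, the same change as that from compound 1 to compound 2. Because that earlier change gave a 1.1-fold lower number from compound 1 to compound 2 (0.04 log units; within the scatter), the step for compound 4 is expected to be small as well, a step that the limit leaves unreadable from compound 3 to compound 4. On that basis compound 4 is estimated at 35 uM in this assay, with a likely range from 18 uM to 70 uM, and a good chance that only a limit is reported again.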

Compound 4, half-maximal toxic concentration: 17 uM
Estimate against measurement, compound 4: 2.1-fold (0.31 log units) above; measured number outside the range, below it.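

Carried over to the core of compound 3, dipropylamino in place of tert-butyl on a saturated chain carbon bound to a triple-bonded carbon gave, in this assay, an at least 1.8-fold lower number from compound 3 to compound 4 (0.27 log units; that floor lies within the scatter). The starting point of that step is a limit and not a number: the limit of > 32 uM in this assay, at which 1 of the 4 values shown sits. The result therefore shows neither that the change acts alike on both cores nor that it acts differently: the same change on two cores in this assay, a 1.1-fold lower number (0.04 log units; within the scatter) from compound 1 to compound 2 and an at least 1.8-fold lower number (0.27 log units; that floor lies within the scatter) from compound 3 to compound 4; the limit leaves it open whether they differ.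

The compounds shown leave open what number compound 3 would give if it could be read exactly, and so how large the step on its core really is. They also leave open whether other groups at the same place, such as dimethylamino, morpholine or a carboxylic acid, would give similar steps on the two cores in this assay.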